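The source may report more compounds than this note shows. Statements on the series, on what has been measured and on what is new or still open speak of the compounds shown alone.

Measured so far in a functional assay (aorta) for antagonist activity, with Oryctolagus cuniculus as the target; on this read-out lower numbers stand for stronger inhibition and higher numbers for weaker inhibition:

- compound 1, `CCCCc1ccc(CNC(=O)OC(C)(C)C)c(=O)n1Cc1ccc(-c2ccccc2-c2nn[nH]n2)cc1` — 10 nM
- compound 2, `CCCCc1ccc(CN)c(=O)n1Cc1ccc(-c2ccccc2-c2nn[nH]n2)cc1` — 20 nM
- compound 3, `CCCCc1ccc(CN(Cc2ccccc2)C(C)=O)c(=O)n1Cc1ccc(-c2ccccc2-c2nn[nH]n2)cc1` — 1 nM

Compound 2 gives the highest of the three numbers in this assay, so of the three it inhibits least strongly. Its nearest neighbour is compound 1, which differs only by the step of a 2.0-fold higher number from compound 1 to compound 2 (0.30 log units; within the scatter), a change of hydrogen in place of tert-butoxycarbonyl on the amine nitrogen that stays within the scatter. The step of a 20-fold lower number from compound 2 to compound 3 (1.30 log units; beyond the scatter) is the large one, and a 10-fold lower number from compound 1 to compound 3 (1.00 log units; beyond the scatter) points the same way.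

Compound 4, `CCCCc1ccc(CN(C)S(C)(=O)=O)c(=O)n1Cc1ccc(-c2ccccc2-c2nn[nH]n2)cc1`, is obtained from compound 2 by methyl(methylsulfonyl)amino in place of amino on a saturated chain carbon bound to an aromatic carbon. As in compound 3, the nitrogen carries two substituents instead of two hydrogens, but the entering group is smaller than acetyl(benzyl)amino and brings no ring. The step toward compound 3 is the closest guide, so a drop in number is expected for compound 4, though less than a 20-fold lower number from compound 2 to compound 3 (1.30 log units; beyond the scatter), giving an expected 4.0-fold lower number from compound 2 to compound 4 (0.60 log units; beyond the scatter). Compound 4 is therefore estimated at 5 nM, within the range 2 nM to 15 nM.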

Compound 4, half-maximal inhibitory concentration: 0.2 nM
For compound 4 the middle estimate is 25-fold (1.40 log units) above the measured one, and the stated range ends above it.
By their numbers in this assay, from the lowest: compound 4; then compound 3; then compounds 1 and 2 (each within the scatter of the next).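

In this assay, methyl(methylsulfonyl)amino gives the largest step yet seen on this saturated chain carbon, a 100-fold lower number from compound 2 to compound 4 (2.00 log units; beyond the scatter), and it also beats both substituted amines, with a 50-fold lower number from compound 1 to compound 4 (1.70 log units; beyond the scatter) and a 5.0-fold lower number from compound 3 to compound 4 (0.70 log units; beyond the scatter). A low number here therefore does not need the ring of acetyl(benzyl)amino, since an entering group with no ring goes lower still. No measurement shown here explains why this group does so well.

The new group differs from amino in both a methyl and a methylsulfonyl on the nitrogen, so the compounds shown cannot say which of the two carries the gain. Methylsulfonylamino, with its hydrogen kept on the nitrogen, and acetyl(methyl)amino, with a carbonyl in place of the sulfonyl, would each separate those two parts.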